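Cytotoxicity notes: hexylsulfanyl in place of pentyloxy

The source may hold more compounds than are shown below. What is called first, only, known or untested is meant among the compounds shown, and "the series" means these compounds.

Measured so far:
Compound 1, `CCCCCCCCOc1nc(N)nc2c1ncn2/C=C1/CC1(CO)CO`, gives in an ADME assay on Akata cells (Homo sapiens) for cytotoxicity, with a stated time of 7 days (on this read-out higher numbers stand for lower toxicity in this test and lower numbers for higher toxicity in this test), the value > 20000 nM, a limit of the assay and not a number.
Compound 2, `CC(C)CNc1nc(N)nc2c1ncn2/C=C1/CC1(CO)CO`, gives in this assay the value > 24000 nM, again a limit.
Compound 3, `CCCCCOc1nc(N)nc2c1ncn2/C=C1/CC1(CO)CO`, gives in this assay the value > 20000 nM, again a limit.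

Compound 3 thus stands at a limit, as do the other two; two of the three values sit at the limit of > 20000 nM in this assay, at which 2 of the 3 values shown sit, and one at the limit of > 24000 nM in this assay, at which 1 of the 3 values shown sits. The steps that reach compound 3, a step that the two limits leave unreadable from compound 1 to compound 3 and a step that the two limits leave unreadable from compound 2 to compound 3, are therefore unreadable in size, and so is a step that the two limits leave unreadable from compound 1 to compound 2. Among the compounds with values here, no measured step gives a direction or a size.

Compound 4, `CCCCCCSc1nc(N)nc2c1ncn2/C=C1/CC1(CO)CO`, differs from compound 3 by hexylsulfanyl in place of pentyloxy on an aromatic carbon. With every measured value at a limit, nothing supports an expectation of a step beyond the scatter in this assay in either direction. Compound 4 is therefore expected to remain at the limit in this assay, with an estimated step that the limit leaves unreadable from compound 3 to compound 4. The estimate for compound 4 in this assay is 30000 nM, in the range 10000 nM to 100000 nM.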

Compound 4, half-maximal cytotoxic concentration: > 20000 nM
Compound 4 was reported as a limit; the forecaster's own chance of this, stated with the estimate: 80%; the middle value is on the limit's open side.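

Compound 4, like compound 1, compound 2 and compound 3, stands at a limit in this assay, so none of the steps joining these four compounds can be read. The compounds shown leave open whether any substituent at this aromatic carbon changes the half-maximal cytotoxic concentration, and in which direction.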